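A few compounds are considered here, and "the series" means these few. Any claim that something is new, unique, unknown or untested is made for them only; others in the source may bear on it.

Measured values in a functional assay (blood) for inhibition, with Homo sapiens as the target; a higher number here means a weaker inhibitor, a lower number a stronger inhibitor:
compound 1, `CO/N=C(\C)c1ccc(Sc2cc(F)cc(C3CCOCC3)c2)cc1`: 110 nM
compound 2, `C/C(=N\OCCSc1nnc(C)s1)c1ccc(Sc2cc(F)cc(C3CCOCC3)c2)cc1`: 230 nM
compound 3, `C/C(=N\OCCF)c1ccc(Sc2cc(F)cc(C3CCOCC3)c2)cc1`: 40 nM

Compound 3 stands lowest of the three in this assay, with a 2.8-fold lower number from compound 1 to compound 3 (0.44 log units; beyond the scatter) to its nearest neighbour and a 5.8-fold lower number from compound 2 to compound 3 (0.76 log units; beyond the scatter) to the furthest. Compound 4, `C/C(=N\OCCSc1nnnn1C)c1ccc(Sc2cc(F)cc(C3CCOCC3)c2)cc1`, is unmeasured; against compound 3 the change is (1-methyl-1H-tetrazol-5-yl)sulfanyl in place of fluoro on a saturated chain carbon, two bonds along the chain from an oxygen. The step that bears on it most directly is a 5.8-fold lower number from compound 2 to compound 3 (0.76 log units; beyond the scatter), the same kind of exchange at the same place run in the opposite direction; a 2.1-fold higher number from compound 1 to compound 2 (0.32 log units; beyond the scatter) points the same way. A modestly higher number is therefore expected for compound 4 in this assay, with the step estimated as a 5.0-fold higher number from compound 3 to compound 4 (0.70 log units; beyond the scatter). Compound 4 is thus estimated at 200 nM, range 90 nM to 450 nM.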

Compound 4, half-maximal inhibitory concentration: 120 nM
For compound 4 the middle estimate is 1.7-fold (0.22 log units) above the measured one; measured number inside the range.
By their numbers in this assay, from the lowest: compound 3; then compounds 1, 4 and 2 (each within the scatter of the next, the first and the last beyond it).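

In this assay, at this place on a saturated chain carbon, two bonds along the chain from an oxygen, a second aromatic sulfanyl group also stays behind fluoro: a 3.0-fold higher number from compound 3 to compound 4 (0.48 log units; beyond the scatter). Changing the ring on the sulfur from 5-methyl-1,3,4-thiadiazol-2-yl to 1-methyl-1H-tetrazol-5-yl gives a 1.9-fold lower number from compound 2 to compound 4 (0.28 log units; within the scatter), so these two rings are not told apart here. Against hydrogen, the ((1-methyl-1H-tetrazol-5-yl)sulfanyl)methyl group gives a 1.1-fold higher number from compound 1 to compound 4 (0.04 log units; within the scatter), leaving the two level.

On these data alone, whether an amine, a carboxylic acid or a longer chain ending in fluoro at this place would match compound 3 stays open. Nothing available here accounts for the gap between fluoro and the sulfanyl groups.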